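A dimethylphenyl group replaces a chlorophenyl group

A few compounds are considered here, and "the series" means these few. Any claim that something is new, unique, unknown or untested is made for them only; others in the source may bear on it.

- compound 1 `CC(C)(C)OC(=O)N1CCN(C(=S)Sc2ccc(Br)cc2)CC1` gives 1820 nM
- compound 2 `Cc1ccccc1SC(=S)N1CCN(C(=O)OC(C)(C)C)CC1` gives 2270 nM
- compound 3 `CC(C)(C)OC(=O)N1CCN(C(=S)Sc2ccccc2Cl)CC1` gives 1560 nM

In a functional assay on A549 cells (Homo sapiens) for antiproliferative activity, read by MTT assay, with a stated time of 72 h (a lower number here means a stronger inhibitor, a higher number a weaker inhibitor), compound 3 lies within the scatter of both other compounds. Changing the group on the sulfur has so far moved the number little: a 1.2-fold higher number from compound 1 to compound 2 (0.10 log units; within the scatter) and a 1.2-fold lower number from compound 1 to compound 3 (0.07 log units; within the scatter). Compound 4 `Cc1ccc(C)c(SC(=S)N2CCN(C(=O)OC(C)(C)C)CC2)c1` brings a new change, (2,5-dimethylphenyl in place of 2-chlorophenyl on a sulfur), with 2,5-dimethylphenyl in place of 2-chlorophenyl on a sulfur. The closest guide is chloro in place of methyl, a 1.5-fold lower number from compound 2 to compound 3 (0.16 log units; within the scatter), read in reverse. A small rise in this assay is therefore expected, with no step beyond the scatter, and the estimated change is a 1.3-fold higher number from compound 3 to compound 4 (0.13 log units; within the scatter). For compound 4 the estimate is 2100 nM, with an expected range from 1000 nM to 4000 nM.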

Compound 4, half-maximal inhibitory concentration: 539 nM
Estimate against measurement, compound 4: 3.9-fold (0.59 log units) above; measured number below the stated range.
By their numbers in this assay, from the lowest: compound 4; then compounds 3, 1 and 2 (each within the scatter of the next).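

In this assay the group on the sulfur turns out to matter, which the earlier swaps within the scatter did not show: 2,5-dimethylphenyl gives a 2.9-fold lower number from compound 3 to compound 4 (0.46 log units; beyond the scatter) and a 3.4-fold lower number from compound 1 to compound 4 (0.53 log units; beyond the scatter). The largest change, a 4.2-fold lower number from compound 2 to compound 4 (0.62 log units; beyond the scatter), comes from methyl in place of hydrogen on an aromatic carbon, so this single change is enough to pass the scatter. Nothing measured here explains the gain.

Still open, as far as these compounds go, is whether larger groups such as ethyl or isopropyl would lower the number further. An amine or a carboxylic acid on the aromatic ring is also untested in the compounds shown.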